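This account rests on a few compounds, and the source may have more. Where it says the series, first, only, none or still open, it means among the compounds named here.

Going by the values given here, in a functional assay on K562 cells (Homo sapiens) for inhibition, read by sulforhodamine B assay, with a stated time of 48 h (on this read-out lower numbers stand for stronger inhibition of growth and higher numbers for weaker inhibition of growth), compound 1 (`COc1ccc(NC(=S)N/N=C/c2cccs2)cc1`) gives 1700 nM and compound 2 (`CCc1ccc(NC(=S)N/N=C/c2cccs2)cc1`) gives 1600 nM, so compound 2 stands level with the only other measured compound, within the scatter. Compound 3 (`S=C(N/N=C/c1cccs1)Nc1ccc(Br)cc1`) has bromo in place of ethyl on an aromatic carbon. Among the compounds with values here, the one measured step, ethyl in place of methoxy on an aromatic carbon (a 1.1-fold lower number from compound 1 to compound 2 (0.03 log units; within the scatter)), stayed within the scatter, though a single step is thin evidence. No shift beyond the scatter is therefore expected in this assay, and the estimated step is small (a 1.1-fold lower number from compound 2 to compound 3 (0.03 log units; within the scatter)). For compound 3 the expected value is 1500 nM (estimated range 700 nM to 3200 nM).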

Compound 3, concentration for 50% growth inhibition: > 100000 nM
Compound 3: a limit, no number; the forecaster's own chance of this, stated with the estimate: 2%; middle value at least 66-fold (1.82 log units) away from the limit.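

In this assay compound 3 gives > 100000 nM, which is a limit and not a number: the limit of > 100000 nM in this assay, at which 1 of the 3 values shown sits. Bromo in place of ethyl gives an at least 62-fold higher number from compound 2 to compound 3 (1.79 log units; beyond the scatter), and bromo in place of methoxy gives an at least 58-fold higher number from compound 1 to compound 3 (1.76 log units; beyond the scatter). This aromatic carbon is therefore not indifferent to its group: methoxy and ethyl stand level here, while bromo gives no measured growth inhibition up to the limit of the assay. On these data alone, whether chloro, fluoro or an amine at this carbon would behave like bromo or like ethyl stays open. The reason for the loss also stays open.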